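Replacing the aryl group on a weak acid

The source may hold more compounds than are shown below. What is called first, only, known or untested is meant among the compounds shown, and "the series" means these compounds.

Compound 1 `O=C(O)C1=Cc2ccccc2OC1(OCc1cc(-c2ccc(F)cc2)no1)C(F)(F)F` was examined in a functional assay on DU-145 cells (Homo sapiens) for inhibition, read by MTT assay, with a stated time of 24 h (a lower number here means a stronger inhibitor, a higher number a weaker inhibitor), where compound 1 gives 168000 nM, the highest of the two numbers at hand. Among the measured compounds shown here, the only neighbour is compound 2 `CCOC(=O)C1=Cc2ccccc2OC1(OCc1cc(-c2ccc(F)cc2)no1)C(F)(F)F`, the ethyl ester, which in this assay gives 53500 nM; the step of a 3.1-fold lower number from compound 1 to compound 2 (0.50 log units; beyond the scatter) concerns the oxygen next to the carbonyl group and is the sole measured step in the set.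

Compound 3 `O=C(O)C1=Cc2ccccc2OC1(OCc1cc(-c2cccc(C(F)(F)F)c2)no1)C(F)(F)F` keeps the acid of compound 1 and changes only the aryl group: 3-(trifluoromethyl)phenyl in place of 4-fluorophenyl on an aromatic carbon. For the measured compounds named here, no measured step touches this part of the molecule, so the step from compound 1 to compound 2 cannot be carried over; it merely shows that this assay can register a modest change for a single alteration. With nothing to point in either direction, compound 3 is expected to stay close to compound 1, the expected step being a 1.1-fold lower number from compound 1 to compound 3 (0.05 log units; within the scatter) and probably not beyond the scatter. Compound 3 is therefore estimated at 150000 nM in this assay, within a range from 50000 nM to 450000 nM.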

Compound 3, half-maximal inhibitory concentration: 155000 nM
Beside the measured number, compound 3's estimate is 1.0-fold (0.01 log units) below it, and the stated range covers the measured number.
By their numbers in this assay, from the lowest: compound 2; then compounds 3 and 1 (each within the scatter of the next).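

In this assay, putting 3-(trifluoromethyl)phenyl in place of 4-fluorophenyl gives a 1.1-fold lower number from compound 1 to compound 3 (0.03 log units; within the scatter), so the two acids cannot be told apart. Among the compounds shown here, this is the first reading at this place, on an aromatic carbon of a five-membered aromatic ring with 1 nitrogen and 1 oxygen, and the entering group, with 10 heavy atoms against 7, leaves the number within the scatter; of the two single changes measured on compound 1, only the ester step, a 3.1-fold lower number from compound 1 to compound 2 (0.50 log units; beyond the scatter), lies beyond it. Nothing at hand accounts for either reading.

Going by these compounds, what remains open is whether the same aryl exchange would also leave the ethyl ester, compound 2, within the scatter, since the exchange has been read only on the acid. On these data alone, it is equally open whether this place tolerates any aryl group in this assay, as a phenyl ring carrying an amine or a nitrile, or a pyridine ring in place of the phenyl, could give a number that differs from those of compound 1 and compound 3.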